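Clearance notes: replacing 3-cyanophenyl in compound 2

A few compounds are considered here, and "the series" means these few. Any claim that something is new, unique, unknown or untested is made for them only; others in the source may bear on it.

Compound 1 `CCNC(=O)[C@H]1CC[C@@H](n2/c(=N/C(=O)c3ccccc3)[nH]c3ccc(CN4CCCCC4)cc32)CC1`: 194 mL.min-1.g-1
Compound 2 `CC(C)NC(=O)[C@H]1CC[C@@H](n2/c(=N/C(=O)c3cccc(C#N)c3)[nH]c3ccc(CN4CCC(C(C)(C)O)CC4)cc32)CC1`: 72 mL.min-1.g-1

In an in vitro ADME assay on microsomes from liver (Homo sapiens) for metabolic stability (a lower number here means slower removal, a higher number faster removal of the compound), compound 2 holds the lower of the two numbers at 72 mL.min-1.g-1. Its nearest neighbour is compound 1 at 194 mL.min-1.g-1, and this gap lies beyond the usual scatter. The two compounds differ in more than one place, so their gap cannot be tied to any single change.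

Compound 3 `CC(C)NC(=O)[C@H]1CC[C@@H](n2/c(=N/C(=O)c3ccc(F)c(Cl)c3)[nH]c3ccc(CN4CCC(C(C)(C)O)CC4)cc32)CC1` departs from compound 2 in one place: 3-chloro-4-fluorophenyl stands in place of 3-cyanophenyl on a carbonyl carbon (3-chloro-4-fluorophenyl in place of 3-cyanophenyl on a carbonyl carbon). Going by the values given here, no measured pair shows this replacement, so the expectation below is a judgement with a wide margin, anchored on compound 2 at 72 mL.min-1.g-1.

A small rise in this assay is expected, not clearly beyond the scatter: the estimated change is a 1.4-fold higher number from compound 2 to compound 3 (0.14 log units; within the scatter). No change at all would also fit this expectation.

For compound 3 the estimated value is 100 mL.min-1.g-1, with an expected range of 55 mL.min-1.g-1 to 180 mL.min-1.g-1.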

Compound 3, intrinsic clearance in microsomes: 83 mL.min-1.g-1
Estimate against measurement, compound 3: 1.2-fold (0.08 log units) above; low and high end bracket the measured number.
By their numbers in this assay, from the lowest: compounds 2 and 3 (each within the scatter of the next); then compound 1.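

In this assay, putting 3-chloro-4-fluorophenyl in place of 3-cyanophenyl on a carbonyl carbon, with the rest of the molecule held constant, gives a 1.2-fold higher number from compound 2 to compound 3 (0.06 log units; within the scatter), so compound 2 and compound 3 cannot be told apart in this read-out. Going by these compounds alone, this is the first reading at this position, as compound 1 and compound 2 differ in more than one place and their gap cannot be assigned to any one of them. Here, a group with a triple bond and a hydrogen-bond acceptor gives way to one with fluorine and chlorine and no hydrogen-bond acceptor, without a difference that stands clear of the scatter, and no measurement at hand accounts for this result.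

Compound 1, at 194 mL.min-1.g-1, carries an unsubstituted phenyl on the carbonyl carbon but also differs elsewhere, so the contribution of the substituents on that ring remains unread. From the compounds shown here alone, it also remains open whether a ring bearing an amine or a carboxylic acid, or a saturated cyclohexyl group, on this carbonyl carbon would stay within the scatter of compound 2 and compound 3 in this assay.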